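The source may hold more compounds than are shown below. What is called first, only, known or untested is meant among the compounds shown, and "the series" means these compounds.

Working notes on the series. The shared core carries a pyridin-2-yl on the chain in compound 1 `O[C@@H](c1ccccc1)[C@H]1CO[C@H](c2ccccc2)[C@@H](C/C=C/c2ccccn2)C1`, which in a functional assay on HeLa cells (Homo sapiens) for cytotoxicity, read by WST assay, with a stated time of 48 h (a higher number here means a weaker inhibitor, a lower number a stronger inhibitor), gives 33800 nM. Compound 2 `COc1ccccc1/C=C/C[C@H]1C[C@@H]([C@@H](O)c2ccccc2)CO[C@@H]1c1ccccc1` gives 14700 nM, and compound 3 `O=[N+]([O-])c1ccccc1/C=C/C[C@H]1C[C@@H]([C@@H](O)c2ccccc2)CO[C@@H]1c1ccccc1` gives 11800 nM. Compound 3 holds the lowest of the three numbers, though its separation from compound 2 stays within the scatter; only compound 1 sits clearly apart from it.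

Among the measured compounds shown here, the steps so far: a 2.3-fold lower number from compound 1 to compound 2 (0.36 log units; beyond the scatter) and a 2.9-fold lower number from compound 1 to compound 3 (0.46 log units; beyond the scatter), while a 1.2-fold lower number from compound 2 to compound 3 (0.10 log units; within the scatter). So the two ring-substituted phenyls behave alike, and the exchange of one ring substituent for another has not moved the number.

Compound 4 `Oc1ccc(/C=C/C[C@H]2C[C@@H]([C@@H](O)c3ccccc3)CO[C@@H]2c2ccccc2)cc1` is not yet measured. Relative to compound 3 the change is 4-hydroxyphenyl in place of 2-nitrophenyl on a double-bonded chain carbon bound to a double-bonded chain carbon.

For the measured compounds named here, the step from compound 2 to compound 3 bears most directly, as the only other swap of a substituent on that phenyl, and it lay within the scatter. The two steps from compound 1 show that leaving pyridin-2-yl for a substituted phenyl lowered the number modestly, and compound 4 keeps a substituted phenyl. Going by the values given here, no measured step tests a hydroxy on this ring. Compound 4 is therefore expected to land near compound 3, with the step of a 1.3-fold higher number from compound 3 to compound 4 (0.10 log units; within the scatter) expected to stay within the scatter; the estimate for compound 4 in this assay is 15000 nM, ranging from 6000 nM to 40000 nM.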

Compound 4, half-maximal inhibitory concentration: 14400 nM
For compound 4 the middle estimate is 1.0-fold (0.02 log units) above the measured one; the range from low to high includes it.
By their numbers in this assay, from the lowest: compounds 3, 4 and 2 (each within the scatter of the next); then compound 1.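

In this assay, the step to 4-hydroxyphenyl gives a 1.2-fold higher number from compound 3 to compound 4 (0.09 log units; within the scatter) and a 1.0-fold lower number from compound 2 to compound 4 (0.01 log units; within the scatter), so 2-nitrophenyl, 2-methoxyphenyl and 4-hydroxyphenyl cannot be told apart on this double-bonded chain carbon, even though the change from 2-nitrophenyl alters the hydrogen-bond donor and acceptor counts and the substituent named on the ring. Against pyridin-2-yl the new group gives a 2.3-fold lower number from compound 1 to compound 4 (0.37 log units; beyond the scatter) as its step, which places all three substituted phenyls beyond the scatter from compound 1, and no compound shown goes against this. No measurement shown here explains why these substituents read alike or why compound 1 stands apart from them.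

Still open, as far as these compounds go, is whether an unsubstituted phenyl, or a phenyl carrying an amine or a carboxylic acid, would read with compounds 2, 3 and 4 or would separate from them. No pair shown keeps one substituent and changes only where it sits on the ring, so the 2-substituted and 4-substituted phenyls cannot yet be compared for the same group, and a 4-nitrophenyl or a 2-hydroxyphenyl would be needed to settle this.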